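This account rests on a few compounds, and the source may have more. Where it says the series, first, only, none or still open, it means among the compounds named here.

Measured compounds:
compound 1, `CNS(=O)(=O)Cc1noc2ccccc12`: 23 mg/kg
compound 2, `CCNS(=O)(=O)Cc1noc2ccccc12`: 39 mg/kg

Both were tested in a functional assay on the whole organism (strain STD-dd) with Mus musculus as the target, in the maximal electroshock model, with a stated time of 2 h; a lower number here means that less compound is needed, a higher number that more compound is needed for the effect. Compound 1 gives the lowest of the two numbers, and its nearest neighbour is compound 2, reached by a 1.7-fold higher number from compound 1 to compound 2 (0.23 log units; within the scatter), a step that stays within the scatter. That step is methyl in place of hydrogen on a saturated chain carbon bound to a sulfonamide nitrogen.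

Compound 3, `CNS(=O)(=O)Cc1noc2ccc(Cl)cc12`, has not yet been measured. Compared with compound 1, the difference is chloro in place of hydrogen on an aromatic carbon. The chloro sits on an aromatic carbon of a six-membered aromatic ring of carbon only, part of a fused or bridged system of two rings. Within the data shown here, no measured step touches that ring; the only known step, a 1.7-fold higher number from compound 1 to compound 2 (0.23 log units; within the scatter), concerns the sulfonamide side chain and is within the scatter, so it offers no guide to an aromatic change. With nothing pointing either way, the expectation is a step no larger than the scatter in either direction. For compound 3 the estimated step is a 1.2-fold lower number from compound 1 to compound 3 (0.06 log units; within the scatter). Compound 3 is therefore expected to give 20 mg/kg, with a range from 10 mg/kg to 45 mg/kg.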

Compound 3, dose for half-maximal effect: 20 mg/kg
For compound 3 middle estimate and measured number coincide at the digits printed, within the range that was stated.
By their numbers in this assay, from the lowest: compounds 3, 1 and 2 (each within the scatter of the next).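

In this assay the change of chloro in place of hydrogen on an aromatic carbon (a 1.2-fold lower number from compound 1 to compound 3 (0.06 log units; within the scatter)) gives the first reading from the six-membered aromatic ring of carbon only, since the earlier step between compound 1 and compound 2 concerned only the sulfonamide side chain. The result shows that this carbon of the core of compound 1 accepts a chloro group with a step that stays within the scatter, so in this whole-animal test the ring position, like the side chain, has so far produced no step beyond the scatter. No measured information bears on why the number of compound 3 stays this close to that of compound 1, and a single substituent at one position cannot establish a trend for the ring.

What the compounds shown leave open is whether a different group at this same carbon, such as a methoxy group, an amine or a carboxylic acid, would also stay within the scatter, and whether chloro behaves alike on the other aromatic carbons of the ring. They also leave open how chloro would combine with a longer chain on the sulfonamide nitrogen.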